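The source may report more compounds than this note shows. Statements on the series, on what has been measured and on what is new or still open speak of the compounds shown alone.

Measured compounds:
Compound 1 `COc1ccc(NC(=O)/C=C/c2coc3cc(OC)ccc3c2=O)cc1`: in a functional assay on A549 cells (Homo sapiens) for inhibition, read by MTT assay, with a stated time of 48 h (a lower number here means a stronger inhibitor, a higher number a weaker inhibitor), compound 1 gives 23000 nM.
Compound 2 `COc1ccc(NC(=O)/C=C/c2coc3cc(O)ccc3c2=O)cc1`: in this assay compound 2 gives 12800 nM.
Compound 3 `COc1ccc2c(=O)c(/C=C/C(=O)NCc3ccc(F)cc3F)coc2c1`: in this assay compound 3 gives 13300 nM.

Compound 2 differs from compound 1 by hydrogen in place of methyl on an oxygen on an aromatic ring, and this step gave a 1.8-fold lower number from compound 1 to compound 2 (0.25 log units; within the scatter). Compound 3 differs from compound 1 by 2,4-difluorobenzyl in place of 4-methoxyphenyl on an amide-type nitrogen, with a 1.7-fold lower number from compound 1 to compound 3 (0.24 log units; within the scatter). Compound 3 and compound 2 are not joined by a counted step; their two values lie close together.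

Compound 4 `O=C(/C=C/c1coc2cc(O)ccc2c1=O)NCc1ccc(F)cc1F` is not yet measured. It differs from compound 3 by hydrogen in place of methyl on an oxygen on an aromatic ring, the same change that separates compound 1 from compound 2, at a place described in the same words. Compound 4 is expected to show a step of about a 1.7-fold lower number from compound 3 to compound 4 (0.22 log units; within the scatter) in this assay, resting on the step from compound 1 to compound 2 a 1.8-fold lower number from compound 1 to compound 2 (0.25 log units; within the scatter). Compound 4 is therefore estimated at 8000 nM, expected between 3500 nM and 20000 nM.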

Compound 4, half-maximal inhibitory concentration: 6610 nM
Compound 4: the middle estimate sits 1.2-fold (0.08 log units) above what was measured; the range from low to high includes it.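

In this assay, the change from methoxy to hydroxy on the core of compound 3 gave a 2.0-fold lower number from compound 3 to compound 4 (0.30 log units; within the scatter). Set beside the same change on the core of compound 1, the two steps agree: the same change on two cores in this assay, a 1.8-fold lower number (0.25 log units; within the scatter) from compound 1 to compound 2 and a 2.0-fold lower number (0.30 log units; within the scatter) from compound 3 to compound 4, 1.1-fold (0.05 log units) apart, within the scatter of two such steps. This shows that the change carried across these two cores with no difference that can be told apart, but each step lies within the scatter, so it does not show that the change itself has a real effect, and two pairs make no rule for the wider series.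

The compounds shown leave open what an amine or a longer alkoxy chain would give in place of the hydroxy group. They also leave open whether the step would hold on a core with a carboxylic acid on the amide side chain.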